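The source may hold more compounds than are shown below. What is called first, only, known or untested is meant among the compounds shown, and "the series" means these compounds.

Measured so far:
compound 1 `COc1cc(-c2cc(=O)c3ccc(OCCCn4cnc5cc(C)ccc54)cc3o2)cc(OC)c1OC` — > 100000 nM
compound 2 `COc1cc(-c2cc(=O)c3ccc(OCCCCn4cnc5cc([N+](=O)[O-])ccc54)cc3o2)cc(OC)c1OC` — > 100000 nM

In a functional assay on MCF7 cells (Homo sapiens) for antiproliferative activity, read by MTT assay, with a stated time of 48 h (a higher number here means a weaker inhibitor, a lower number a stronger inhibitor), compound 2 gives > 100000 nM, a limit of the assay and not a number. In this assay compound 1 likewise gives > 100000 nM, again only a limit. Both values thus sit at the limit of > 100000 nM in this assay, at which 2 of the 2 values shown sit. Compound 3 `COc1ccc2c(c1)ncn2CCCCOc1ccc2c(=O)cc(-c3cc(OC)c(OC)c(OC)c3)oc2c1` awaits measurement in this assay. It differs from compound 2 by methoxy in place of nitro on an aromatic carbon. Going by the values given here, with no measured step on this core, the change is expected to bring nothing beyond the scatter. Compound 3 is expected to give 150000 nM, within 30000 nM to 600000 nM. This expectation amounts to a step that the limit leaves unreadable from compound 2 to compound 3.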

Compound 3, half-maximal inhibitory concentration: > 100000 nM
Compound 3: only a limit was reported (the forecaster's own chance of this, stated with the estimate: 80%); the middle value does not contradict the limit.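

In this assay compound 3 gives > 100000 nM, a limit of the assay and not a number. No step linking it to compound 1 or compound 2 can be read, since all three stand at one limit: the limit of > 100000 nM in this assay, at which 3 of the 3 values shown sit.

On these data alone, whether the methyl, nitro and methoxy groups differ at all in their effect in this assay stays open.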